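Fluoro to hydrogen on the anilino series

The compounds below may be only part of what the source reports. "The series", "measured", "known", "first", "only" and "open" are said of these compounds alone.

Values in a functional assay on MCF7 cells (Homo sapiens) for inhibition, read by sulforhodamine B assay; a higher number here means a weaker inhibitor, a lower number a stronger inhibitor:
compound 1 `O=C1C(Nc2ccc(I)cc2)=CC(=O)c2c1nc1n2[C@H]2OC[C@@H](O)[C@H]2OC1`: 3890 nM
compound 2 `O=C1C(Nc2ccccc2F)=CC(=O)c2c1nc1n2[C@H]2OC[C@@H](O)[C@H]2OC1`: > 4000 nM, a limit and not a number
compound 3 `O=C1C(Nc2ccccc2)=CC(=O)c2c1nc1n2[C@H]2OC[C@@H](O)[C@H]2OC1`: not yet measured

Compound 2 stands at > 4000 nM in this assay, which is a limit of the assay. The change to compound 3 is hydrogen in place of fluoro on an aromatic carbon. For the measured compounds named here, one measured step bears on it, an at least 1.0-fold higher number from compound 1 to compound 2 (0.01 log units; that floor lies within the scatter), and it also changes the group on the amine nitrogen. Since that step is open on one side, no step beyond the scatter is expected, and the expected step is a number no higher from compound 2 to compound 3 (the limit leaves the size open). Compound 3 is estimated at 4000 nM, with an expected range from 1800 nM to 9000 nM.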

Compound 3, half-maximal inhibitory concentration: > 4000 nM
Compound 3: no number, only a limit; the forecaster's own chance of this, stated with the estimate: 45%; the middle value lies on the limit itself.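

With fluoro gone, the plain anilino compound 3 also stands at a limit, not a number, so hydrogen at this aromatic carbon gives no readable value in this assay. Hydrogen in place of iodo gives an at least 1.0-fold higher number from compound 1 to compound 3 (0.01 log units; that floor lies within the scatter), so this step shows no gain or loss beyond the scatter. The step between compound 2 and compound 3 cannot be read, since both stand at a limit: the limit of > 4000 nM in this assay, at which 2 of the 3 values shown sit.

As far as these compounds go, whether fluoro and hydrogen differ at all on this ring stays open. So does whether a methoxy group or an amine on the phenyl ring would give a value clearly stronger than that of compound 1.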